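The source may report more compounds than this note shows. Statements on the series, on what has been measured and on what is new or still open speak of the compounds shown alone.

Values measured so far in an ADME assay (liver) for metabolic stability, with Liver microsome (Rattus norvegicus) as the target, read by LC-MS, using microsomes, with a stated time of 30 min, tested at 4 uM (a higher number here means that more of the compound is left, a lower number that less of the compound is left), are:

- Compound 1 `Cc1nc(N2CCN(C)CC2)c2nc(-c3cccc(Cl)c3)n(C3CCOCC3)c2n1` gives 45%
- Compound 2 `Cc1nc(N2CCN(C)CC2)c2nc(-c3ccccc3C(F)(F)F)n(C3CCOCC3)c2n1` gives 38%
- Compound 3 `COc1ccccc1-c1nc2c(N3CCN(C)CC3)nc(C)nc2n1C1CCOCC1` gives 35%

Within the usual scatter, compound 3 cannot be told apart from the other two. One step reaching it is a number 10 percentage points lower from compound 1 to compound 3 (within the scatter) with 2-methoxyphenyl in place of 3-chlorophenyl. Another is a number 3 percentage points lower from compound 2 to compound 3 (within the scatter) with methoxy in place of trifluoromethyl. The remaining step, a number 7 percentage points lower from compound 1 to compound 2 (within the scatter) with 2-(trifluoromethyl)phenyl in place of 3-chlorophenyl, is equally unresolved.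

Compound 4 `COc1cccc(-c2nc3c(N4CCN(C)CC4)nc(C)nc3n2C2CCOCC2)c1` carries 3-methoxyphenyl in place of 2-methoxyphenyl on an aromatic carbon, and the change is counted as 3-methoxyphenyl in place of 2-methoxyphenyl on an aromatic carbon with the same atoms joined differently. For the measured compounds named here, no measured pair makes exactly this swap, so the evidence is indirect. All three steps above stay within the scatter, which gives no reason to expect a large move. The closest name among the measured groups is the 3-chlorophenyl of compound 1, which gives 45% and suggests only a slight upward lean.

The expected step is a number 5 percentage points higher from compound 3 to compound 4 (within the scatter) and nothing clearly beyond the scatter is anticipated. In this assay compound 4 is estimated at 40% within an expected range of 27% to 53% overall.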

Compound 4, percent of the compound remaining: 30%
Compound 4: middle estimate off by 10 percentage points, on the high side; the range from low to high includes it.
By their numbers in this assay, from the lowest: compounds 4, 3, 2 and 1 (each within the scatter of the next, the first and the last beyond it).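

In this assay, the swap of 2-methoxyphenyl for 3-methoxyphenyl at this place on the core comes with a number 5 percentage points lower from compound 3 to compound 4 (within the scatter), and 3-methoxyphenyl in place of 2-(trifluoromethyl)phenyl comes with a number 8 percentage points lower from compound 2 to compound 4 (within the scatter), so neither change can be told apart from no change at all. For the compounds shown here, the new result does give the first step in this set that clears the scatter, a number 15 percentage points lower from compound 1 to compound 4 (beyond the scatter), with methoxy in place of chloro on the phenyl ring, although this step is modest and compounds 2 and 3 each remain within the scatter of both compound 1 and compound 4. No measurement at hand accounts for this gap.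

As far as these compounds go, whether the gap holds for other groups at this place stays open, for example a phenyl ring carrying a nitrile or an amine, or 3-(trifluoromethyl)phenyl, which would pair directly with compound 2. All four compounds also share the oxan-4-yl group and the rest of the core, so these values cannot show how much those parts contribute to the amount of compound left.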